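The compounds below may be only part of what the source reports. "The series", "measured", "known", "first", "only" and "open" are said of these compounds alone.

Four compounds built on one shared core are compared in a functional assay on HepG2 cells (Homo sapiens) for cytotoxicity, read by MTT assay, with a stated time of 72 h; a higher number here means a weaker inhibitor, a lower number a stronger inhibitor. Compound 1, `Cc1cc(=O)n(-c2ccccc2OC(F)(F)F)nc1C(=O)Nc1ccc(Oc2ncnc3sccc23)cc1`, gives 14400 nM in this assay. Compound 2, `Cc1cc(=O)n(-c2cccc(F)c2)nc1C(=O)Nc1ccc(Oc2ncnc3sccc23)cc1`, shows 3-fluorophenyl in place of 2-(trifluoromethoxy)phenyl on an aromatic nitrogen relative to compound 1; in this assay compound 2 gives 18500 nM, and the step is a 1.3-fold higher number from compound 1 to compound 2 (0.11 log units; within the scatter). Compound 3, `Cc1cc(=O)n(-c2ccccc2OC(F)(F)F)nc1C(=O)Nc1ccc(Oc2ncnc3sccc23)c(F)c1`, carries fluoro in place of hydrogen on an aromatic carbon relative to compound 1. In this assay compound 3 reaches only a limit of the measurement, > 40000 nM. Across that change the step is an at least 2.7-fold higher number from compound 1 to compound 3 (0.44 log units; beyond the scatter), and this comparison rests on (the limit of > 40000 nM in this assay, at which 1 of the 3 values shown sits). Compound 4, `Cc1cc(=O)n(-c2cccc(F)c2)nc1C(=O)Nc1ccc(Oc2ncnc3sccc23)c(F)c1`, has not been measured. It differs from compound 3 by 3-fluorophenyl in place of 2-(trifluoromethoxy)phenyl on an aromatic nitrogen, which is the same change that led from compound 1 to compound 2, made at a place described in the same words. Because the earlier step was a 1.3-fold higher number from compound 1 to compound 2 (0.11 log units; within the scatter), the expected step for compound 4 is a step that the limit leaves unreadable from compound 3 to compound 4. Compound 4 is therefore estimated at 55000 nM, with a likely range from 25000 nM to 120000 nM, and it is expected that this assay may again report only a limit for compound 4.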

Compound 4, half-maximal inhibitory concentration: 24500 nM
The estimate for compound 4 lay 2.2-fold (0.35 log units) above the measured number; the measured number lies below the stated range.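

In this assay, placing 3-fluorophenyl in place of 2-(trifluoromethoxy)phenyl on the core of compound 3 gives an at least 1.6-fold lower number from compound 3 to compound 4 (0.21 log units; that floor lies within the scatter), and this can be set beside the same change on the core of compound 1: the same change on two cores in this assay, a 1.3-fold higher number (0.11 log units; within the scatter) from compound 1 to compound 2 and an at least 1.6-fold lower number (0.21 log units; that floor lies within the scatter) from compound 3 to compound 4; the limit leaves it open whether they differ. Carrying the other change, fluoro in place of hydrogen on an aromatic carbon, onto the core of compound 2 gives a 1.3-fold higher number from compound 2 to compound 4 (0.12 log units; within the scatter), which can be compared with its earlier step: the same change on two cores in this assay, an at least 2.7-fold higher number (0.44 log units; beyond the scatter) from compound 1 to compound 3 and a 1.3-fold higher number (0.12 log units; within the scatter) from compound 2 to compound 4; the limit leaves it open whether they differ. Compound 3 gives only a limit of the measurement, > 40000 nM, so these pairs show neither that each change keeps its size from one core to the other nor that it does not: the limit of > 40000 nM in this assay, at which 1 of the 4 values shown sits.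

On these data alone, how far compound 3 really lies from compound 1 and compound 4 stays open. The compounds shown also leave open how this assay would respond to an amine or a carboxylic acid on that aromatic carbon, or to a longer chain on the aromatic nitrogen.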